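Replacing the isopropylsulfonyl group on compound 2 with a dimethylcarbamoylmethyl group

The source may hold more compounds than are shown below. What is called first, only, known or untested is meant among the compounds shown, and "the series" means these compounds.

Of the compounds shown here, two of a shared core have been tested so far. Compound 1 `CC(C)(C)COC(=O)N1CCC(Oc2ncnc3c2CCN3c2ccc(S(C)(=O)=O)cc2F)CC1` carries a neopentyloxycarbonyl group on the ring amine nitrogen, and in a functional assay on CHO-K1 cells for agonist activity at Glucose-dependent insulinotropic receptor (Homo sapiens), read by a luciferase reporter, with a stated time of 5 h (a higher number here means that more compound is needed for the effect, a lower number that less compound is needed), compound 1 gives 39.8 nM. Among the measured compounds shown here, compound 2 `CC(C)S(=O)(=O)N1CCC(Oc2ncnc3c2CCN3c2ccc(S(C)(=O)=O)cc2F)CC1` carries an isopropylsulfonyl group in the same position, and in this assay compound 2 gives 1260 nM, the highest of the two numbers; the only measured step, a 32-fold higher number from compound 1 to compound 2 (1.50 log units; beyond the scatter), is large and beyond the scatter, so compound 2 stands well apart from compound 1.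

Compound 3 `CN(C)C(=O)CN1CCC(Oc2ncnc3c2CCN3c2ccc(S(C)(=O)=O)cc2F)CC1` is not yet measured. It differs from compound 2 in one place: (dimethylcarbamoyl)methyl in place of isopropylsulfonyl on an amine nitrogen in a ring. For the measured compounds named here, no measured step exchanges a sulfonyl group for an amide-bearing chain, so the single known step from compound 1 to compound 2 bears on it only loosely: it shows that this position tolerates a large change in the number, in either direction, and nothing more. With no closer guide, compound 3 is expected to stay near compound 2, with a step of a 1.6-fold higher number from compound 2 to compound 3 (0.20 log units; within the scatter) that may well lie within the scatter. Compound 3 is therefore estimated at 2000 nM in this assay, with a wide range from 400 nM to 10000 nM.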

Compound 3, half-maximal effective concentration: > 10000 nM
Compound 3 ended at the assay's limit (the forecaster's own chance of this, stated with the estimate: 20%); middle value at least 5.0-fold (0.69 log units) from the limit.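

In this assay, the reading for compound 3 is a limit of the assay and not a number: the limit of > 10000 nM in this assay, at which 1 of the 3 values shown sits. On the amine nitrogen in a ring, (dimethylcarbamoyl)methyl in place of isopropylsulfonyl gives an at least 7.9-fold higher number from compound 2 to compound 3 (0.89 log units; beyond the scatter), even though the leaving and entering groups have 6 heavy atoms each and neither has a ring or a hydrogen-bond donor, so these counts alone do not settle the number at this position. Set against neopentyloxycarbonyl, the same group gives an at least 250-fold higher number from compound 1 to compound 3 (2.40 log units; beyond the scatter), which leaves the three compounds in a clear order, with compound 1 needing the least compound and compound 3 the most, every step among them lying beyond the scatter.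

As far as these compounds go, the true size of both new steps stays open, since each has only a lower bound. Also open, from the compounds shown here alone, is whether a shorter carbamate such as ethoxycarbonyl, a urea, or a plain alkyl chain on the same nitrogen would bring the number back towards that of compound 1, or whether neopentyloxycarbonyl stands alone here.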